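The source may report more compounds than this note shows. Statements on the series, on what has been measured and on what is new or still open speak of the compounds shown alone.

Of the compounds shown here, three have been tested in a functional assay on L1210 cells (Mus musculus) for antiproliferative activity; a higher number here means a more potent compound, by a factor of ten per unit of this negative logarithm, a lower number a less potent compound. Compound 1 `CN(C)/N=N/c1cccc(C(N)=O)c1` gives 3.8. Compound 2 `CN(C)/N=N/c1ccc([N+](=O)[O-])cc1C(N)=O`, which carries both a nitro group and a carbamoyl group on its aromatic ring, gives 3.26. Compound 3 `CCOC(=O)c1[nH]cnc1/N=N/N(C)CCO`, built on a different core, gives 3.38. Of these three numbers, compound 2 has the lowest, though compound 3 lies within the usual scatter of it, so the two cannot be separated; compound 1 lies beyond the scatter above it.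

Compound 4 `CN(C)/N=N/c1ccc(S(N)(=O)=O)cc1C(N)=O` has not yet been measured. It differs from compound 2 in a single place: sulfamoyl in place of nitro on an aromatic carbon. Going by the values given here, no pair of compounds measured so far differs in just this one way, so there is no measured step to lean on. Compound 1 and compound 3 show only that the whole range covered so far is narrow. With nothing pointing clearly one way or the other, the step from compound 2 to compound 4 is expected to be a number 0.14 log units higher from compound 2 to compound 4 (within the scatter), small and within the scatter. Compound 4 is therefore estimated to give 3.4, with a range from 2.9 to 3.9.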

Compound 4, logarithm of the reciprocal of the active concentration, log(1/C): 3.32
The estimate for compound 4 lay 0.08 log units above the measured number, and the stated range covers the measured number.
By their numbers in this assay, from the lowest: compounds 2, 4 and 3 (each within the scatter of the next); then compound 1.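

Putting sulfamoyl in place of nitro on this aromatic carbon, meta to a carbamoyl group and para to a group of 5 heavy atoms, gives a number 0.06 log units higher from compound 2 to compound 4 (within the scatter) in this assay and so leaves the two compounds inseparable. Going by these compounds alone, this is the first step in the set where only one place differs, and it gives a direct reading that the earlier compounds, which differ in more than one place, could not provide. At this position, sulfamoyl, with 4 heavy atoms and 1 hydrogen-bond donor, cannot be told apart from nitro, with 3 heavy atoms and 0 hydrogen-bond donors, although the two groups differ in these counts. No measurement available here accounts for this result.

A single step cannot show whether this position tolerates every group or whether these two simply happen to match, and an amine, a carboxylic acid or a longer chain on the same aromatic carbon might give a clearly different number. On these data alone, it also remains open whether the same exchange of nitro for sulfamoyl would be just as silent on a different core, such as that of compound 3.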